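The source may hold more compounds than are shown below. What is called first, only, known or untested is meant among the compounds shown, and "the series" means these compounds.

Measured compounds in an ADME assay on HEK-293T cells (Homo sapiens) for cytotoxicity, read by MTT assay, tested at 25 uM; a lower number here means a stronger effect, a higher number a weaker effect of the compound at the concentration tested:
compound 1 `COc1ccc(O)c(C(=O)Nc2ncc([N+](=O)[O-])s2)c1` — 100%
compound 2 `COc1ccc(OC(C)=O)c(C(=O)Nc2ncc([N+](=O)[O-])s2)c1` — 100%
compound 3 `CC(C)c1cc(C(=O)Nc2ncc([N+](=O)[O-])s2)c(O)c(C(C)C)c1` — 29.4%

Compound 3 gives the lowest of the three numbers in this assay; its gap to compound 1 and to compound 2 is each beyond the scatter, so compound 3 is the one with the strongest effect among those measured.

Compound 4 `CC(=O)Oc1c(C(=O)Nc2ncc([N+](=O)[O-])s2)cc(C(C)C)cc1C(C)C` is not yet measured. It differs from compound 3 by acetyl in place of hydrogen on an oxygen on an aromatic ring.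

Going by the values given here, one measured step bears on this change: no change at the digits printed from compound 1 to compound 2 (within the scatter), the same replacement on the same kind of oxygen, made on the core of compound 1. That step left the read-out unmoved within the scatter. Among the compounds with values here, the expectation for this assay is therefore a step from compound 3 to compound 4 of no size beyond the scatter, in neither direction, with the caution that the one comparable step was taken at the top of the scale, where a change could not have been seen as a rise.

Compound 4 is thus estimated at 32%, range 15% to 60%, the expected step being a number 2.6 percentage points higher from compound 3 to compound 4 (within the scatter).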

Compound 4, a percentage reported as activity, at one concentration (the size of the read-out at that concentration, not a potency): 45.9%
For compound 4 the middle estimate is 13.9 percentage points below the measured one; low and high end bracket the measured number.
By their numbers in this assay, from the lowest: compound 3; then compound 4; then compounds 1 and 2 (each within the scatter of the next).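

In this assay, acetyl in place of hydrogen on an oxygen on an aromatic ring does move the read-out on the core of compound 3, giving a number 16.5 percentage points higher from compound 3 to compound 4 (beyond the scatter). The flat step on the core of compound 1, taken at the top of the scale, therefore does not carry over as a general result for hydroxy to acetoxy. The size of the step depends on the core that carries the change: the same change on two cores in this assay, no change at the digits printed (within the scatter) from compound 1 to compound 2 and a number 16.5 percentage points higher (beyond the scatter) from compound 3 to compound 4, 16.5 percentage points apart, beyond the scatter of two such steps

The compounds shown do not settle whether this step belongs to the acetyl group specifically or would also follow from another group on the same oxygen, such as a methyl ether or a longer acyl chain. They also leave open whether a core of intermediate read-out would give a step of similar size.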